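The source may hold more compounds than are shown below. What is called first, only, known or untested is meant among the compounds shown, and "the series" means these compounds.

Compound 2 `COc1ccc(-c2nnc(N3CCN(C(=O)CN4CCN(c5ccc(OC)cc5)CC4)CC3)nc2-c2ccc(OC)cc2)cc1` carries a 4-methoxyphenyl on an amine nitrogen in a ring; in an ADME assay on NIH3T3 cells (Mus musculus) for cytotoxicity, read by MTT assay, with a stated time of 24 h (a higher number here means a weaker inhibitor, a lower number a stronger inhibitor), compound 2 gives only a limit, > 821000 nM. Compound 1 `COc1ccc(-c2nnc(N3CCN(C(=O)CN4CCN(c5ccccc5Cl)CC4)CC3)nc2-c2ccc(OC)cc2)cc1`, with 2-chlorophenyl in place of that 4-methoxyphenyl, likewise reaches only a limit: in this assay compound 1 gives > 814000 nM. The step that the two limits leave unreadable from compound 1 to compound 2 cannot be read, since the limit of > 814000 nM in this assay, at which 1 of the 2 values shown sits, and the limit of > 821000 nM in this assay, at which 1 of the 2 values shown sits, both end at limits. Compound 3 `COc1ccc(-c2nnc(N3CCN(C(=O)CN4CCN(c5ccc([N+](=O)[O-])cc5)CC4)CC3)nc2-c2ccc(OC)cc2)cc1` differs from compound 2 by nitro in place of methoxy on an aromatic carbon. Among the measured compounds shown here, no measured step bears on this change. Compound 3 is expected to show no step beyond the scatter, an at least 1.0-fold lower number from compound 2 to compound 3 (0.01 log units; that floor lies within the scatter), with an estimate of 800000 nM between 200000 nM and 3000000 nM.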

Compound 3, half-maximal inhibitory concentration: > 801000 nM
Compound 3 ended at the assay's limit; the forecaster's own chance of this, stated with the estimate: 80%; at least 1.0-fold (0.00 log units) between middle value and limit.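

Among the compounds shown here, compound 3, like compound 1 and compound 2, ends at a limit in this assay, so no step among the three can be read. The compounds shown leave open whether 2-chlorophenyl, 4-methoxyphenyl and 4-nitrophenyl differ at all in this read-out.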